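The compounds below may be only part of what the source reports. "The series", "measured", "known", "first", "only" and "open" are said of these compounds alone.

Compound 1, `Cc1c(OCCCCOc2ccc(C(=O)O)cc2)ccc(C(=O)CC2CCCC2)c1C`, gives 16.2% in an assay on HEK293 cells for positive allosteric modulation of metabotropic glutamate receptor 2 (Rattus norvegicus), read by thallium flux, with a stated time of 2.5 min; a higher number here means a larger maximal response, a lower number a smaller maximal response.
Compound 2, `Cc1c(OCCCCOc2ccc(F)c(C(=O)O)c2)ccc(C(=O)CC2CCCC2)c1C`, gives 14.6% in this assay.

Only these two measurements exist, and compound 2 sits within the scatter of compound 1: the change was a number 1.6 percentage points lower from compound 1 to compound 2 (within the scatter). Compound 3, `Cc1c(OCCCCOc2ccc(C(=O)O)c(Cl)c2)ccc(C(=O)CC2CCCC2)c1C`, has not yet been measured in this assay. It differs from compound 2 in one place: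

4-carboxy-3-chlorophenyl in place of 3-carboxy-4-fluorophenyl on an oxygen on a saturated carbon

Within the data shown here, the one measured step that bears on this exchange is the earlier swap of the same aromatic group at the same oxygen, a number 1.6 percentage points lower from compound 1 to compound 2 (within the scatter), which stayed inside the scatter. With nothing else to go on, no movement beyond the scatter is expected in this assay for this second swap either. The step is expected to be a number 0.4 percentage points higher from compound 2 to compound 3 (within the scatter). For compound 3 the estimated maximal response in this assay is 15%, with an expected range from 7% to 25%.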

Compound 3, largest response reached (reported as percent of maximum), in percent of the reference or control that the assay uses: 61.8%
For compound 3 the middle estimate is 46.8 percentage points below the measured one; measured number outside the range, above it.
By their numbers in this assay, from the lowest: compounds 2 and 1 (each within the scatter of the next); then compound 3.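

Among these compounds, the aromatic group on the oxygen is not indifferent in this assay, as the earlier swap within the scatter had left it appearing: with chloro in place of hydrogen on an aromatic carbon as the only change, the response moves a number 45.6 percentage points higher from compound 1 to compound 3 (beyond the scatter). The exchange of 3-carboxy-4-fluorophenyl for 4-carboxy-3-chlorophenyl gives a similarly large step, a number 47.2 percentage points higher from compound 2 to compound 3 (beyond the scatter), but it alters both the halogen and the placing of the carboxylic acid, so it cannot separate the two. No measurement offered here explains why this chloro group has so large an effect.

The compounds shown leave open whether 3-carboxy-4-chlorophenyl or 4-carboxy-3-fluorophenyl would give a similar response. They also leave open whether bromo or methyl could stand in for the chloro group on the 4-carboxyphenyl ring.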